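Swapping a halogen on a hydrazone arm of compound 1

This account rests on a few compounds, and the source may have more. Where it says the series, first, only, none or still open, it means among the compounds named here.

Compound 1 `CCOC(=O)C1=C(N/N=C(/C#N)C(=O)OCC)Nc2[nH]nc(C)c2C1c1ccc(N(C)C)cc1` is one of three compounds with a shared core tested in a functional assay on HepG2 cells (Homo sapiens) for inhibition, read by MTT assay, with a stated time of 48 h; on this read-out lower numbers stand for stronger inhibition and higher numbers for weaker inhibition. In this assay compound 1 gives 46400 nM, the second highest of the three numbers. Compound 2 `CCOC(=O)C1=C(N/N=C(/C(=O)Br)c2ccc(Br)cc2)Nc2[nH]nc(C)c2C1c1ccc(N(C)C)cc1` gives 65000 nM, and a 1.4-fold higher number from compound 1 to compound 2 (0.15 log units; within the scatter). Compound 3 `CCOC(=O)C1=C(NN=C(C#N)C#N)Nc2[nH]nc(C)c2C1c1ccc(N(C)C)cc1` gives 13700 nM, and a 3.4-fold lower number from compound 1 to compound 3 (0.53 log units; beyond the scatter). Compound 4 `CCOC(=O)C1=C(N/N=C(/C(=O)Br)c2ccc(Cl)cc2)Nc2[nH]nc(C)c2C1c1ccc(N(C)C)cc1` is still unmeasured; it differs from compound 1 in that (a group of 12 heavy atoms (8 carbon, 1 nitrogen, 1 oxygen, 1 chlorine, 1 bromine; one six-membered aromatic ring of carbon only) in place of a group of 9 heavy atoms (5 carbon, 2 nitrogen, 2 oxygen; no ring), on an amine nitrogen). The entering group counts one chlorine and one bromine where the group entering in compound 2 counts two bromine, so the step from compound 1 to compound 2 is the closest guide. Because a 1.4-fold higher number from compound 1 to compound 2 (0.15 log units; within the scatter) stayed within the scatter, no step beyond the scatter is expected here. The expected step is a 1.2-fold higher number from compound 1 to compound 4 (0.07 log units; within the scatter). Compound 4 is therefore estimated at 55000 nM, with a range from 25000 nM to 120000 nM.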

Compound 4, half-maximal inhibitory concentration: 50300 nM
For compound 4 the middle estimate is 1.1-fold (0.04 log units) above the measured one, within the range that was stated.
By their numbers in this assay, from the lowest: compound 3; then compounds 1, 4 and 2 (each within the scatter of the next).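

In this assay, chloro in place of bromo on an aromatic carbon (a 1.3-fold lower number from compound 2 to compound 4 (0.11 log units; within the scatter)) leaves compound 2 and compound 4 within the scatter of each other, so this halogen swap does not separate them. The new arm with its aromatic ring also stays within the scatter of the arm of compound 1 (a 1.1-fold higher number from compound 1 to compound 4 (0.04 log units; within the scatter)), while the gap to the two-nitrile arm of compound 3 lies beyond it (a 3.7-fold higher number from compound 3 to compound 4 (0.56 log units; beyond the scatter)). No measurement shown explains these numbers.

On these data alone, what a fluoro or methoxy group on that aromatic ring would give remains open. So does the effect of replacing the bromine on the carbonyl, which compound 2 and compound 4 share, with an amine.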